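Replacing the 3,5-dichloropyridin-4-yl group of compound 2

The compounds below may be only part of what the source reports. "The series", "measured", "known", "first", "only" and "open" are said of these compounds alone.

In an in vivo ADME assay on the whole organism for pharmacokinetics, with Rattus norvegicus as the target (on this read-out lower numbers stand for slow clearance and higher numbers for fast clearance), compound 1 `CC(C)c1onc(COc2c(Cl)cc(F)cc2Cl)c1COc1ccc(/C=C/c2cccc(C(=O)O)c2)c(Cl)c1` gives 15 mL/min/kg. For the measured compounds named here, compound 2 `CC(C)c1onc(-c2c(Cl)cncc2Cl)c1COc1ccc(/C=C/c2cccc(C(=O)O)c2)c(Cl)c1` gives 48 mL/min/kg, the higher of the two numbers measured so far. Compound 3 `CC(C)c1onc(COc2c(Cl)cccc2Cl)c1COc1ccc(/C=C/c2cccc(C(=O)O)c2)c(Cl)c1` has not yet been measured. It departs from compound 2 by one change, (2,6-dichlorophenoxy)methyl in place of 3,5-dichloropyridin-4-yl on an aromatic carbon of the five-membered aromatic ring.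

Going by the values given here, only one measured step bears on this change. It is a 3.2-fold higher number from compound 1 to compound 2 (0.51 log units; beyond the scatter), a modest step beyond the scatter, which put 3,5-dichloropyridin-4-yl in place of (2,6-dichloro-4-fluorophenoxy)methyl at the same place. Among the compounds with values here, the incoming group of compound 3 differs from that departed group only by lacking the fluoro substituent, and no measured step isolates that difference. A step of similar size in the opposite direction is therefore expected in this assay, with some added uncertainty. The expected change is a 2.7-fold lower number from compound 2 to compound 3 (0.43 log units; beyond the scatter). For compound 3 the estimate is 18 mL/min/kg, with an expected range from 8 mL/min/kg to 36 mL/min/kg.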

Compound 3, clearance: 20 mL/min/kg
Compound 3: the middle estimate sits 1.1-fold (0.05 log units) below what was measured; low and high end bracket the measured number.
By their numbers in this assay, from the lowest: compounds 1 and 3 (each within the scatter of the next); then compound 2.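

In this assay, the (2,6-dichlorophenoxy)methyl group in place of 3,5-dichloropyridin-4-yl on this aromatic carbon, next to the ring nitrogen, gives a 2.4-fold lower number from compound 2 to compound 3 (0.38 log units; beyond the scatter), so the gap seen with the fluoro-bearing group also appears without the fluoro substituent. That substituent can now be read on its own: hydrogen in place of fluoro gives a 1.3-fold higher number from compound 1 to compound 3 (0.12 log units; within the scatter), so the fluoro substituent makes no difference that stands out from the scatter on this read-out, and compound 1 and compound 3 cannot be told apart. No measurement of any property accompanies these clearance numbers, so the data offer no explanation for them.

The step to compound 3 changes the six-membered ring's hetero atom and the attachment through the oxygen and methylene together, so a 2,6-dichlorophenyl group set directly on the same carbon would be needed to separate the two. From the compounds shown here alone, it also remains open whether a methoxy group or a nitrile on the aromatic carbon that carries fluoro in compound 1 would stay as close to compound 3 as fluoro does.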